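The source may report more compounds than this note shows. Statements on the series, on what has been measured and on what is new or still open speak of the compounds shown alone.

Measured compounds in a functional assay on SV5A8 cells (Homo sapiens) for cytotoxicity; a higher number here means a weaker inhibitor, a lower number a stronger inhibitor:
Compound 1 `Cc1ccc2c(NCc3ccc(NC(=O)C4CCN(Cc5ccccc5)CC4)cc3)nc(N3CCNC(CCO)C3)nc2c1`: > 8420 nM, a limit of the assay.
Compound 2 `Cc1ccc2c(NCc3ccc(NC(=O)C4CCN(Cc5ccccc5)CC4)cc3)nc(N3CCCCCC3)nc2c1`: > 6880 nM, a limit of the assay.

Compound 2 stands at a limit in this assay; its value is not a number. Compound 1 also stands at a limit, so the step that the two limits leave unreadable from compound 1 to compound 2 cannot be read, as the limit of > 6880 nM in this assay, at which 1 of the 2 values shown sits, and the limit of > 8420 nM in this assay, at which 1 of the 2 values shown sits, show.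

Compound 3 `Cc1ccc2c(NCc3ccc(NC(=O)C4CCN(Cc5ccccc5)CC4)cc3)nc(N3CCN(C)CC3)nc2c1` differs from compound 2 in one place: 4-methylpiperazin-1-yl in place of azepan-1-yl on an aromatic carbon. Going by the values given here, the only measured step touching this carbon, a step that the two limits leave unreadable from compound 1 to compound 2, is unreadable and gives no size to carry over; the two limits show only that neither ring at this position brought the value into the measured range of this assay. No change beyond the scatter is therefore expected, and the estimated step is a step that the limit leaves unreadable from compound 2 to compound 3. Compound 3 is expected at 10000 nM, within 3000 nM to 30000 nM, and most likely it will again be reported only as a limit.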

Compound 3, half-maximal inhibitory concentration: > 17700 nM
Compound 3 was reported as a limit (the forecaster's own chance of this, stated with the estimate: 75%); middle value at least 1.7-fold (0.24 log units) from the limit.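

Compound 3 gives > 17700 nM in this assay, a limit of the assay. Compound 1 and compound 2 also stand at limits, so neither step to compound 3 can be read. The compounds shown leave open how the three rings on this aromatic carbon rank, and whether any ring there gives a value within the measured range.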